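Replacing a Small Ring with an Open Chain

A few compounds are considered here, and "the series" means these few. Any claim that something is new, unique, unknown or untested is made for them only; others in the source may bear on it.

Measured compounds:
Compound 1 `O=C(O)C1CC1c1ccc(C#Cc2cc(Cl)nc(Cl)c2)cc1`: 96%
Compound 2 `O=C(O)CCc1ccc(C#Cc2ccc(Cl)nc2)cc1`: 98%
Compound 3 `Cc1cc(C#Cc2ccc(CCC(=O)O)cc2)ccn1`: 102%

In an in vitro functional assay on 1321-N1 cells for agonist activity at Free fatty acid receptor 1 (Homo sapiens), read by fluorescence, spectrophotometry and calcium flux (on this read-out lower numbers stand for smaller maximal responses and higher numbers for larger maximal responses), compound 1 gives the lowest of the three numbers, but compound 2 lies only slightly higher and compound 3 a little further up, and both gaps fall within the scatter, so the three compounds cannot be told apart on this read-out. Compound 4 `O=C(O)CCc1ccc(C#Cc2cc(Cl)nc(Cl)c2)cc1` has not yet been tested. It differs from compound 1 in one place: 2-carboxyethyl in place of 2-carboxycyclopropyl on an aromatic carbon. Compounds 2 and 3 already carry the 2-carboxyethyl group and give full responses, so no step beyond the scatter is expected in this assay in either direction. Compound 4 is therefore estimated to reach 98%, between 88% and 108%, meaning an expected a number 2 percentage points higher from compound 1 to compound 4 (within the scatter).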

Compound 4, largest response reached (reported as efficacy), in percent of the reference or control that the assay uses: 103%
For compound 4 the middle estimate is 5 percentage points below the measured one, and the stated range covers the measured number.
By their numbers in this assay, from the lowest: compounds 1, 2, 3 and 4 (each within the scatter of the next).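

In this assay, putting 2-carboxyethyl in place of 2-carboxycyclopropyl gives a number 7 percentage points higher from compound 1 to compound 4 (within the scatter). For the compounds shown here, this is the first comparison here of two compounds differing in this one place, and it shows that on the core of compound 1 the three-membered ring can be opened without a change in maximal response beyond the scatter. Nothing available explains this result. Still open, on these data alone, is whether a longer chain ending in the same carboxylic acid, or an amide in place of that acid, would keep this full response. Maximal response also leaves open how much of each compound is needed to reach it.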